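Adding 1-hydroxyethyl to an aromatic carbon of compound 1

The compounds below may be only part of what the source reports. "The series", "measured", "known", "first", "only" and "open" are said of these compounds alone.

In a functional assay on the whole organism with Mus musculus as the target (a higher number here means that more compound is needed for the effect, a lower number that less compound is needed), compound 1 `CN(c1ccncc1)n1cccc1` gives > 20 mg/kg, which is a limit and not a number. Compound 2 `CCCCN(c1ccncc1)n1cccc1` gives > 20 mg/kg, also a limit. Compound 3 `c1ccc(CN(c2ccncc2)n2cccc2)cc1` gives > 20 mg/kg, again a limit. Among them lie a step that the two limits leave unreadable from compound 1 to compound 2, a step that the two limits leave unreadable from compound 1 to compound 3 and a step that the two limits leave unreadable from compound 2 to compound 3, all at a saturated chain carbon bound to a nitrogen on an aromatic ring. Compound 4 `CC(O)c1ccn(N(C)c2ccncc2)c1` changes elsewhere: 1-hydroxyethyl in place of hydrogen on an aromatic carbon. For the measured compounds named here, no measured step touches that place, so none sets a size or direction. The expected change, resting on no readable step, is a number no higher from compound 1 to compound 4 (the limit leaves the size open). For compound 4 the estimated value is 20 mg/kg, with an expected range from 7 mg/kg to 40 mg/kg.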

Compound 4, dose for half-maximal effect: 10 mg/kg
Estimate against measurement, compound 4: 2.0-fold (0.30 log units) above; low and high end bracket the measured number.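

Compound 1, compound 2 and compound 3 each stand at a limit and not at a number, so the steps among them cannot be read: the limit of > 20 mg/kg in this assay, at which 3 of the 4 values shown sit. In this assay, the change on the aromatic carbon, two ring bonds from the ring nitrogen, gives the first readable number, with 1-hydroxyethyl in place of hydrogen producing an at least 2.0-fold lower number from compound 1 to compound 4 (0.30 log units; that floor lies within the scatter). From the compounds shown here alone, that floor alone does not establish a real gain, and the true size stays open. Whether the hydroxyl itself matters remains unsettled. Ethyl, acetyl or an amine at this place would bear on that.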